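The compounds below may be only part of what the source reports. "The series", "measured", "known", "first", "only" and "open" are said of these compounds alone.

Of the compounds shown here, three with a shared core have been measured so far in a functional assay on SK-BR-3 cells (Homo sapiens) for antiproliferative activity; a lower number here means a stronger inhibitor, a higher number a weaker inhibitor. Compound 1 (`CC(=O)Oc1ccc(C(=O)Nc2cc3ccc(OCC4CCCN(C)C4)c(C)c3oc2=O)cc1CC=C(C)C`) gives 740 nM and compound 2 (`CC(=O)Oc1ccc(C(=O)Nc2cc3ccc(OCC4CCN(C)C4)c(C)c3oc2=O)cc1CC=C(C)C`) gives 880 nM there, while compound 3 (`CC(C)=CCc1cc(C(=O)Nc2cc3ccc(OCCCN4CCCC4)c(C)c3oc2=O)ccc1O`) gives 720 nM and so stands within the scatter of both others. Compound 4 (`CC(C)=CCc1cc(C(=O)Nc2cc3ccc(OCCCN(C)C(C)C)c(C)c3oc2=O)ccc1O`) departs from compound 3 in a single place. The difference is isopropyl(methyl)amino in place of pyrrolidin-1-yl on a saturated chain carbon, three bonds along the chain from an oxygen on an aromatic ring and it takes away the five-membered ring of pyrrolidin-1-yl, since isopropyl(methyl)amino has no ring. Within the data shown here, only one measured step bears on this, and only loosely: a 1.2-fold higher number from compound 1 to compound 2 (0.08 log units; within the scatter) is a swap of one ring for another, 1-methylpyrrolidin-3-yl in place of 1-methylpiperidin-3-yl, and it stays within the scatter. Among the measured compounds shown here, no measured pair replaces a ring with an open group, so the evidence for this change is thin. With that step so small and compound 3 at 720 nM in line with the other two, no shift beyond the scatter is expected. The expected change is a 1.0-fold higher number from compound 3 to compound 4 (0.02 log units; within the scatter) on this estimate. Compound 4 is estimated at 750 nM in this assay and is expected to fall between 350 nM and 1600 nM.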

Compound 4, half-maximal inhibitory concentration: 570 nM
Beside the measured number, compound 4's estimate is 1.3-fold (0.12 log units) above it; low and high end bracket the measured number.
By their numbers in this assay, from the lowest: compounds 4, 3, 1 and 2 (each within the scatter of the next).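

In this assay, isopropyl(methyl)amino in place of pyrrolidin-1-yl, on a saturated chain carbon three bonds along the chain from an oxygen on an aromatic ring, gives a 1.3-fold lower number from compound 3 to compound 4 (0.10 log units; within the scatter). Among these compounds, this is the first measured pair in which a ring gives way to an open group, and like the ring-for-ring swap in a 1.2-fold higher number from compound 1 to compound 2 (0.08 log units; within the scatter), it stays within the scatter, so for this pair the five-membered ring of pyrrolidin-1-yl can go without a shift that can be told from the scatter. Nothing in the data explains why the two groups read alike.

The compounds shown leave open whether a morpholine, a piperazine or a primary amine at the end of this chain would stay within the scatter of compound 3, and whether a chain shorter or longer than the propyl chain of 3-(isopropyl(methyl)amino)propyl would do the same. On these data alone, it also remains open whether an open amine like isopropyl(methyl)amino would read the same on a compound carrying the acetate of compound 1 in place of the free hydroxyl of compound 3.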